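The source may report more compounds than this note shows. Statements on the series, on what has been measured and on what is new or still open speak of the compounds shown alone.

Of the compounds shown here, three sharing one core have been measured in a functional assay on SNB-75 cells (Homo sapiens) for inhibition, with a stated time of 48 h; on this read-out lower numbers stand for stronger inhibition of growth and higher numbers for weaker inhibition of growth. Compound 1 (`COc1ccccc1/C=C/C(=O)c1c(O)cc2occc2c1OC`) gives 7490 nM, compound 2 (`COc1c(C(=O)/C=C/c2ccc(Cl)cc2)c(O)c(Br)c2occc12`) gives 1800 nM, and compound 3 (`C=CCc1c(O)c(C(=O)/C=C/c2ccccc2)c(OC)c2ccoc12`) gives 1390 nM. Compound 3 thus stands within the usual scatter of compound 2, while the number of compound 1 lies higher, beyond that scatter.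

Compound 4 (`C=CCc1c(O)c(C(=O)/C=C/c2ccc(Cl)cc2)c(OC)c2ccoc12`) departs from compound 3 in one place: chloro in place of hydrogen on an aromatic carbon. This puts chloro in place of hydrogen on an aromatic carbon, para to a large group, turning phenyl into 4-chlorophenyl.

Among the measured compounds shown here, no pair of measured compounds isolates this change. The nearest guide is compound 2, which carries the same 4-chlorophenyl but differs elsewhere as well. Compound 2 gives 1800 nM and compound 3 gives 1390 nM, two values within the scatter of each other. In this assay, no step beyond the scatter is therefore expected. The estimated change is a 1.2-fold lower number from compound 3 to compound 4 (0.06 log units; within the scatter). Compound 4 is expected at 1200 nM, with an estimated range from 550 nM to 2600 nM.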

Compound 4, concentration for 50% growth inhibition: 2010 nM
The estimate for compound 4 lay 1.7-fold (0.22 log units) below the measured number; low and high end bracket the measured number.
By their numbers in this assay, from the lowest: compounds 3, 2 and 4 (each within the scatter of the next); then compound 1.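

Read in this assay, chloro in place of hydrogen on an aromatic carbon, para to a large group, gives a 1.4-fold higher number from compound 3 to compound 4 (0.16 log units; within the scatter) and so, in the one direct reading of this change, turning phenyl into 4-chlorophenyl leaves the number within the scatter. Allyl in place of bromo on an aromatic carbon gives a 1.1-fold higher number from compound 2 to compound 4 (0.05 log units; within the scatter) and so shows that, with 4-chlorophenyl in place, these two groups cannot be told apart on this read-out. Nothing at hand speaks to what lies behind either result.

On these data alone, whether an amine or a carboxylic acid in place of the chloro would carry the number beyond the scatter remains open. So does whether a longer chain, such as prenyl in place of allyl, would do so.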